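The compounds below may be only part of what the source reports. "The series", "measured", "known", "first", "only" and "open" are said of these compounds alone.

Measured so far in a functional assay on NCI-H460 cells (Homo sapiens) for cytotoxicity, read by MTT assay; a lower number here means a stronger inhibitor, a higher number a weaker inhibitor:

compound 1 `CCc1cc(S(=O)(=O)N2C[C@H](c3ccccc3)NC2=O)ccc1NC(=O)c1ccc(N)cc1`: 670 nM
compound 2 `Cc1cc(S(=O)(=O)N2C(=O)N[C@@H](c3ccccc3)C2C)ccc1NC(=O)c1ccc([N+](=O)[O-])cc1`: a limit of the assay, > 10000 nM
compound 3 `CCOC(=O)Nc1c(C)cc(S(=O)(=O)N2C[C@H](c3ccccc3)NC2=O)cc1C`: a limit of the assay, > 10000 nM

Compound 1 is the only one of the three with a number in this assay. For compound 2 the reading is a limit and not a number. For compound 3 the reading is likewise a limit. Among the compounds with values here, both of those sit at the limit of > 10000 nM in this assay, at which 2 of the 3 values shown sit, so the series gives a single anchor and no measured step from which a structure–activity trend could be read.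

Compound 4 `CCc1cc(S(=O)(=O)N2C[C@H](c3ccccc3)NC2=O)ccc1NC(=O)OCC(C)C` follows from compound 1 by the change isobutoxy in place of 4-aminophenyl on a carbonyl carbon: the 4-aminophenyl leaves and isobutoxy enters on the carbonyl carbon whose other neighbour is the amide-type nitrogen, so that the ((4-aminophenyl)carbonyl)amino of compound 1 becomes (isobutoxycarbonyl)amino. Within the data shown here, no measured pair isolates this change. The shared core is kept, and the rest of compound 1 is untouched.

The expectation for compound 4 is a step in this assay of a 7.5-fold higher number from compound 1 to compound 4 (0.87 log units; beyond the scatter), towards weaker inhibition and beyond the usual scatter. The estimate for compound 4 is 5000 nM, with a range from 1500 nM to 20000 nM, and a fair chance that the assay reports only a limit.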

Compound 4, half-maximal inhibitory concentration: 80 nM
Compound 4: the middle estimate sits 63-fold (1.80 log units) above what was measured; measured number below the stated range.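

In this assay, within the data shown here, the first measured step is an 8.4-fold lower number from compound 1 to compound 4 (0.92 log units; beyond the scatter), with isobutoxy in place of 4-aminophenyl on a carbonyl carbon. At this position on the shared core, the six-membered aromatic ring and the amino group of the 4-aminophenyl are therefore not needed for activity, and a group with no ring gives the lower number. Nothing measured here accounts for the size or direction of this step.

From the compounds shown here alone, whether the gain is specific to isobutoxy remains open, as does the outcome with a longer chain such as hexyloxy, with benzyloxy, or with a dimethylamino group on the same carbonyl carbon. Compound 2 and compound 3 differ from compound 4 in more than one place and each reads only as a limit, so neither gives a step: the limit of > 10000 nM in this assay, at which 2 of the 4 values shown sit.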